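Dopamine transporter series: a second methoxy on compound 2

The source may hold more compounds than are shown below. What is called first, only, known or untested is meant among the compounds shown, and "the series" means these compounds.

Compound 2 `COc1ccc(C(O)CCN2CC=C(Cc3ccccc3)CC2)cc1` gives 57% in an assay on CHO cells for inhibition of sodium-dependent dopamine transporter (Homo sapiens), read by scintillation counting, with a stated time of 10 min, tested at 10 uM (a higher number here means more inhibition at the concentration tested (going by the name of the read-out), a lower number less inhibition), the higher of the two numbers in hand; compound 1 `Cc1ccc(C(O)CCN2CC=C(Cc3ccccc3)CC2)cc1` gives 30%. Among the compounds with values here, the only measured step, a number 27 percentage points higher from compound 1 to compound 2 (beyond the scatter), was modest and beyond the scatter. Compound 3 `COc1ccc(C(O)CCN2CC=C(Cc3ccccc3)CC2)cc1OC` differs from compound 2 by methoxy in place of hydrogen on an aromatic carbon. Within the data shown here, no measured step covers this kind of change; the one step known concerns a different exchange at another aromatic carbon, so it bears only loosely. A step no larger than the scatter is therefore expected. Compound 3 is expected to give 60%, within 40% to 78%. This expected step, a number 3 percentage points higher from compound 2 to compound 3 (within the scatter), is expected to lie within the scatter.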

Compound 3, a percentage reported as inhibition, at one concentration (the size of the read-out at that concentration, not a potency): 61%
Compound 3: the middle estimate sits 1 percentage points below what was measured, and the stated range covers the measured number.
By their numbers in this assay, from the lowest: compound 1; then compounds 2 and 3 (each within the scatter of the next).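

In this assay, methoxy in place of hydrogen, ortho to a methoxy group and meta to a large group, leaves the read-out within the scatter (a number 4 percentage points higher from compound 2 to compound 3 (within the scatter)). This aromatic position therefore accepts a second methoxy without a step beyond the scatter, unlike the earlier exchange of methyl for methoxy (a number 27 percentage points higher from compound 1 to compound 2 (beyond the scatter)). No available evidence bears on this result.

Open, as far as these compounds go, is whether ethoxy, hydroxy, fluorine or an amine at this position would give a step beyond the scatter. Also open, from the compounds shown here alone, is how compound 3 would behave as a potency rather than at a single concentration.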